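Trifluoromethyl in Place of Bromo: a Flat Step Expected

A few compounds are considered here, and "the series" means these few. Any claim that something is new, unique, unknown or untested is made for them only; others in the source may bear on it.

Of the compounds shown here, three built on one shared core have been measured in a functional assay on PC-12 cells (Rattus norvegicus) for cytotoxicity, read by MTT assay, with stated times of 2 h and 24 h, tested at 1 uM; a higher number here means a stronger effect of the compound at the concentration tested, a lower number a weaker effect. Compound 1 `Cc1ccc(-n2nc(-c3ccc(C(F)(F)F)cc3O)nc2-c2ccccc2O)cc1` gives 71.5%, compound 2 `CC(C)c1ccc(-n2nc(-c3ccc(C(F)(F)F)cc3O)nc2-c2ccccc2O)cc1` gives 69.7%, and compound 3 `Oc1cc(C(F)(F)F)ccc1-c1nc(-c2ccccc2O)n(-c2ccc(Br)cc2)n1` gives 69.4%. Compound 3 holds the lowest of the three numbers, but its neighbours sit very close: the measured steps were a number 1.8 percentage points lower from compound 1 to compound 2 (within the scatter), a number 2.1 percentage points lower from compound 1 to compound 3 (within the scatter) and a number 0.3 percentage points lower from compound 2 to compound 3 (within the scatter), every one of them within the scatter. Compound 4 `Oc1cc(C(F)(F)F)ccc1-c1nc(-c2ccccc2O)n(-c2ccc(C(F)(F)F)cc2)n1` differs from compound 3 in a single place: trifluoromethyl in place of bromo on an aromatic carbon. All three measured steps exchanged the group on this same aromatic carbon, moving among methyl, isopropyl and bromo, and none of them shifted the read-out beyond the scatter. With three exchanges at this spot leaving the number essentially where it was, the expectation for trifluoromethyl in place of bromo is likewise a step of no size beyond the scatter in this assay, in either direction. Compound 4 is therefore expected to give about 69%, with a range from 59% to 79%. The expected step is a number 0.4 percentage points lower from compound 3 to compound 4 (within the scatter).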

Compound 4, a percentage reported as activity, at one concentration (the size of the read-out at that concentration, not a potency): 70.7%
Compound 4: middle estimate off by 1.7 percentage points, on the low side, and the stated range covers the measured number.
By their numbers in this assay, from the lowest: compounds 3, 2, 4 and 1 (each within the scatter of the next).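

In this assay, trifluoromethyl brings 4 heavy atoms where bromo has 1, yet the result is a number 1.3 percentage points higher from compound 3 to compound 4 (within the scatter), alongside a number 1 percentage points higher from compound 2 to compound 4 (within the scatter) and a number 0.8 percentage points lower from compound 1 to compound 4 (within the scatter). This adds a fourth group on this aromatic carbon, para to a large group, and none of the four compounds separates from the others, so across methyl, isopropyl, bromo and trifluoromethyl the read-out does not respond to the exchange. Nothing at hand explains why the number stays so level at this position.

The compounds shown leave open whether an amine, a carboxylic acid or a longer chain on this same carbon would move the number beyond the scatter. They also leave open whether changes to the shared core itself would matter more than changes at this position.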